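The source may report more compounds than this note shows. Statements on the series, on what has been measured and on what is new or still open speak of the compounds shown alone.

For the measured compounds named here, in a toxicity assay on THP-1 cells (Homo sapiens) for cytotoxicity (a higher number here means that more compound is needed for the effect, a lower number that less compound is needed), compound 1 `Oc1c(-c2nnc(Cc3ccc(Cl)cc3)[nH]2)ncc2cccnc12` gives 31600 nM, the only true number so far. Compound 2 `CNc1ccnc2c(O)c(-c3nc(C)n[nH]3)ncc12` gives > 50100 nM, which is a limit of the assay and not a number. Compound 3 `Cc1n[nH]c(-c2ncc3c(N(C)C)ccnc3c2O)n1` gives > 50100 nM, and this too is only a limit. Compound 3 therefore has no exact position on the scale.

The next compound, compound 4 `Cc1n[nH]c(-c2ncc3c(-c4ccccc4)ccnc3c2O)n1`, has phenyl in place of dimethylamino on an aromatic carbon. Going by the values given here, the one measured step between compounds that differ in one place is a step that the two limits leave unreadable from compound 2 to compound 3, where a methyl replaces a hydrogen on a nitrogen on an aromatic ring. It is a different change and its size cannot be read, so it offers no size to carry over.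

Among the compounds with values here, the only guide to a number is compound 1 at 31600 nM, a loose one since compound 1 differs from compound 4 in more than one place. A modest move towards a lower number in this assay is therefore expected, though the result may again be only a limit. The expected size of this move is an at least 1.4-fold lower number from compound 3 to compound 4 (0.15 log units; that floor lies within the scatter). Compound 4 is estimated at 35000 nM, with an expected range from 12000 nM to 50100 nM.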

Compound 4, half-maximal effective concentration: > 50100 nM
Compound 4 was reported as a limit; the forecaster's own chance of this, stated with the estimate: 45%; at least 1.4-fold (0.15 log units) between middle value and limit.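

Compound 4 is reported only as a limit of the assay and not as a number, like compound 2 and compound 3, so no step among these three compounds can be read, because each one rests on the same limit: the limit of > 50100 nM in this assay, at which 3 of the 4 values shown sit.

From the compounds shown here alone, what stays open is whether phenyl, dimethylamino and methylamino on that aromatic carbon differ at all in this assay.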